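The compounds below may be only part of what the source reports. "The series", "measured", "known", "first", "only" and "open" are said of these compounds alone.

Compounds measured so far in a functional assay for antagonist activity at transient receptor potential cation channel subfamily V member 1 (Rattus norvegicus), read by FLIPR; on this read-out lower numbers stand for lower potency and higher numbers for higher potency (the scale is a negative logarithm):
compound 1 `O=C(Nc1ccccc1Br)N[C@@H]1CCN(c2ccc(Cl)cn2)C1` gives 7.3;
compound 2 `Cc1ccc(N2CC[C@@H](NC(=O)Nc3ccccc3Br)C2)nc1` gives only a limit, < 6.7;
compound 3 `O=C(NCCN1CCc2c(F)cccc21)Nc1ccccc1Br` gives 7.4.

Compound 2 therefore stands at the limit of this assay, not at a number: one of the three values shown sits there (the limit of < 6.7 in this assay, at which 1 of the 3 values shown sits). Among the measured compounds shown here, the one step that reaches compound 2 is a number at least 0.60 log units lower from compound 1 to compound 2 (beyond the scatter), a loss that runs beyond the scatter, so compound 2 is the weakest point the data reach.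

Compound 4 `Cc1cccc(N2CC[C@@H](NC(=O)Nc3ccccc3Br)C2)c1` is not yet measured. It differs from compound 2 in one place: 3-methylphenyl in place of 5-methylpyridin-2-yl on an amine nitrogen in a ring. No measured step covers this change; the only step shown alters a substituent on the aromatic ring and leaves its ring atoms untouched, and compound 3 shares neither the five-membered ring nor the aryl group, so its value shows only that a different scaffold reaches a similar potency to compound 1.

For the measured compounds named here, with compound 2 at the limit, the starting point itself is unknown below that line, and the change has no precedent among the measured steps. Compound 4 is therefore expected to land near where compound 2 stands, at about 6.5, between 5.8 and 7.2. The step from compound 2 is expected to be a step that the limit leaves unreadable from compound 2 to compound 4, that is, no shift beyond the scatter, with a real chance that this assay again reports only a limit.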

Compound 4, negative logarithm of the antagonist equilibrium constant: 7.7
The estimate for compound 4 lay 1.20 log units below the measured number; the whole stated range lies below it.
By their numbers in this assay, from the lowest: compounds 1, 3 and 4 (each within the scatter of the next, the first and the last beyond it). At a limit, below all of these: compound 2.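

In this assay, the group on the amine nitrogen of the five-membered ring proves to be a place where potency moves strongly: 3-methylphenyl in place of 5-methylpyridin-2-yl gives a number at least 1.00 log units higher from compound 2 to compound 4 (beyond the scatter), the first change shown that alters the ring atoms of this group rather than a substituent on it. The value of compound 2 is a limit and not a number: the limit of < 6.7 in this assay, at which 1 of the 4 values shown sits. The comparison with the chloro compound adds a second point, since 3-methylphenyl in place of 5-chloropyridin-2-yl gives a number 0.40 log units higher from compound 1 to compound 4 (beyond the scatter), so a methyl group on this aromatic ring does not in itself go with low potency.

The step to compound 4 swaps the ring nitrogen for carbon and moves the methyl in one change, so the compounds shown cannot say which of the two goes with the gain; a plain phenyl or a 5-methylpyridin-3-yl group at this place would bear on that. As far as these compounds go, it also stays open whether a 3-chlorophenyl group would match the 3-methylphenyl group here.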